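The compounds below may be only part of what the source reports. "The series", "measured", "known", "first", "only" and "open" are said of these compounds alone.

Measured compounds:
- compound 1, `CC(C)=CCC/C(C)=C/CC/C(C)=C/CC[C@@H]1[C@@]2(C)CC/C(=N\OCc3cn(-c4ccc(F)cc4)nn3)C(C)(C)[C@@H]2CC[C@@]1(C)O`: 21400 nM
- compound 2, `CC(C)=CCC/C(C)=C/CC/C(C)=C/CC[C@@H]1[C@@]2(C)CC/C(=N\OCc3cn(-c4cccc(Br)c4)nn3)C(C)(C)[C@@H]2CC[C@@]1(C)O`: 15700 nM
- compound 3, `CC(C)=CCC/C(C)=C/CC/C(C)=C/CC[C@@H]1[C@@]2(C)CC/C(=N\OCc3cn(-c4ccc(F)c(Cl)c4)nn3)C(C)(C)[C@@H]2CC[C@@]1(C)O`: 20100 nM

In a functional assay on HeLa cells (Homo sapiens) for cytotoxicity, read by MTT assay, with a stated time of 48 h (a lower number here means a stronger inhibitor, a higher number a weaker inhibitor), compound 1 gives the highest of the three numbers, yet its gaps to the others are small: a 1.4-fold lower number from compound 1 to compound 2 (0.13 log units; within the scatter) and a 1.1-fold lower number from compound 1 to compound 3 (0.03 log units; within the scatter), both within the scatter, as is a 1.3-fold higher number from compound 2 to compound 3 (0.11 log units; within the scatter). For the measured compounds named here, the three measured values therefore sit at one level, and no compound can be called weaker or stronger than another.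

Compound 4, `CC(C)=CCC/C(C)=C/CC/C(C)=C/CC[C@@H]1[C@@]2(C)CC/C(=N\OCc3cn(-c4ccc(F)c(F)c4F)nn3)C(C)(C)[C@@H]2CC[C@@]1(C)O`, is not yet measured. It differs from compound 1 by 2,3,4-trifluorophenyl in place of 4-fluorophenyl on an aromatic nitrogen. Going by the values given here, the steps that bear on this are those that change the group on the aromatic nitrogen or add a halogen to it: a 1.4-fold lower number from compound 1 to compound 2 (0.13 log units; within the scatter), a 1.1-fold lower number from compound 1 to compound 3 (0.03 log units; within the scatter) and a 1.3-fold higher number from compound 2 to compound 3 (0.11 log units; within the scatter). None of them moved the number beyond the scatter, so no step beyond the scatter is expected in this assay for compound 4 either, in no particular direction.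

Compound 4 is estimated at 19000 nM, with a range from 8500 nM to 42000 nM. The expected step is a 1.1-fold lower number from compound 1 to compound 4 (0.05 log units; within the scatter).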

Compound 4, half-maximal inhibitory concentration: 26200 nM
Beside the measured number, compound 4's estimate is 1.4-fold (0.14 log units) below it, within the range that was stated.
By their numbers in this assay, from the lowest: compounds 2, 3, 1 and 4 (each within the scatter of the next).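

In this assay, 2,3,4-trifluorophenyl on the aromatic nitrogen stays at the level of the earlier aryl groups: a 1.2-fold higher number from compound 1 to compound 4 (0.09 log units; within the scatter), alongside a 1.3-fold higher number from compound 3 to compound 4 (0.12 log units; within the scatter) and a 1.7-fold higher number from compound 2 to compound 4 (0.22 log units; within the scatter). Across compounds 1 to 4, the halogen pattern on this phenyl group can therefore vary, now including a fully adjacent trifluoro pattern, without a step beyond the scatter, and no compound at this position separates from the others. Nothing measured here accounts for this flat result.

Going by these compounds, all four compounds carry a halogenated phenyl group at this place, so it remains open whether an amine or a carboxylic acid on that phenyl group would move the number beyond the scatter. The same question stands for a longer alkyl chain in place of the phenyl group.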